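Adding a second chloro to a fused core: expected outcome

The compounds below may be only part of what the source reports. "The series", "measured", "known", "first", "only" and "open" are said of these compounds alone.

Three compounds have been measured in a functional assay on PC-3 cells (Homo sapiens) for cytotoxicity, read by sulforhodamine B assay, with a stated time of 48 h; on this read-out lower numbers stand for stronger inhibition of growth and higher numbers for weaker inhibition of growth:

Compound 1, `ClCc1ccc(Cn2cnc3c(Cl)ncnc32)cc1`, gives 72400 nM.
Compound 2, `ClCc1cccc(Cn2cnc3ncnc(Cl)c32)c1`, gives 5370 nM.
Compound 3, `ClCc1ccc(Cn2cnc3c(Cl)nc(Cl)nc32)cc1`, gives 7240 nM.

Compound 1 and compound 2 are built from the same atoms joined differently; the difference between the two cores is not broken down here. Their numbers in this assay nonetheless lie well apart, with compound 2 giving the lower one. Compound 3 arises from compound 1 by a single change, (chloro in place of hydrogen on an aromatic carbon), and that change produced a 10-fold lower number from compound 1 to compound 3 (1.00 log units; beyond the scatter). Compound 3 and compound 2 give numbers that lie within the usual scatter of each other.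

The unmeasured compound 4, `ClCc1cccc(Cn2cnc3nc(Cl)nc(Cl)c32)c1`, comes from compound 2 by the same change, (chloro in place of hydrogen on an aromatic carbon), at a place described in exactly the same words. If the change acts as it did before, compound 4 is expected to show a 3.6-fold lower number from compound 2 to compound 4 (0.55 log units; beyond the scatter), a smaller step than the earlier one because compound 2 already gives 5370 nM. In this assay compound 4 is therefore estimated at 1500 nM, most likely between 400 nM and 5500 nM.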

Compound 4, concentration for total growth inhibition: 2880 nM
Estimate against measurement, compound 4: 1.9-fold (0.28 log units) below; the range from low to high includes it.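

In this assay, chloro in place of hydrogen on an aromatic carbon gives a 1.9-fold lower number from compound 2 to compound 4 (0.27 log units; within the scatter) and so has no clear effect on this core, unlike its earlier effect on the core of compound 1. The size of the step therefore did not carry over from one core to the other: the same change on two cores in this assay, a 10-fold lower number (1.00 log units; beyond the scatter) from compound 1 to compound 3 and a 1.9-fold lower number (0.27 log units; within the scatter) from compound 2 to compound 4, 5.4-fold (0.73 log units) apart, beyond the scatter of two such steps. Among the compounds shown here, this shows that a step measured on one core cannot simply be assumed on the other, but with only one pair of compounds per core, it does not show why the two steps differ or what the change would do on any further core.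

The compounds shown leave open what a group other than chloro, such as an amine or a methoxy group, would do at this aromatic carbon between two ring nitrogen atoms. They also leave open whether the two cores would still respond differently with a longer chain in place of the chloromethyl group.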